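This account rests on a few compounds, and the source may have more. Where it says the series, first, only, none or still open, it means among the compounds named here.

Measured so far in a functional assay on MDA-MB-231 cells (Homo sapiens) for inhibition, read by MTT assay, with a stated time of 72 h (a higher number here means a weaker inhibitor, a lower number a stronger inhibitor), are:
- compound 1 `COC(=O)c1ccc(-n2cc(CCCc3nnc(-c4ccc(C)cc4)o3)nn2)cc1` gives 21500 nM
- compound 2 `COC(=O)c1ccc(-c2cn(CCCC(=O)Nc3ccc(C)cc3)nn2)cc1` gives 2700 nM
- compound 3 `Cc1ccc(NC(=O)CCCn2cc(-c3ccc(C(F)(F)F)cc3)nn2)cc1` gives 2300 nM

Compound 2 sits with compound 3 within the scatter, and both numbers lie well under that of compound 1.

Compound 4 `COC(=O)c1ccc(-c2cn(CCCC(=O)Nc3ccc(-c4ccccc4)cc3)nn2)cc1` is not yet measured. It is compound 2 with phenyl in place of methyl on an aromatic carbon, para to a large group, and phenyl in place of methyl on an aromatic carbon gives the counted change.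

Among the compounds with values here, the one measured single-site step is a 1.2-fold lower number from compound 2 to compound 3 (0.07 log units; within the scatter) for trifluoromethyl in place of methoxycarbonyl. That step lies within the scatter and concerns a different site. Within the data shown here, no measured step touches the methyl itself, so the data give no direction for this change. In this assay no step beyond the scatter is therefore expected, and the range is kept wide. The expected change is a 1.1-fold lower number from compound 2 to compound 4 (0.03 log units; within the scatter) as estimated here. For compound 4 the estimate is 2500 nM with an expected range from 800 nM to 9000 nM in this series.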

Compound 4, half-maximal inhibitory concentration: > 100000 nM
Compound 4: a limit, no number; the forecaster's own chance of this, stated with the estimate: 10%; middle value at least 40-fold (1.60 log units) from the limit.
By their numbers in this assay, from the lowest: compounds 3 and 2 (each within the scatter of the next); then compound 1. At a limit, above all of these: compound 4.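

In this assay compound 4 gives > 100000 nM, which is a limit of the assay and not a number. Phenyl in place of methyl on this aromatic carbon, para to a large group, is the first change shown at this site, and it gives an at least 37-fold higher number from compound 2 to compound 4 (1.56 log units; beyond the scatter), so this position does not accept every group, whereas the change at the other site stayed within the scatter: a 1.2-fold lower number from compound 2 to compound 3 (0.07 log units; within the scatter). The size of the new step is only a lower bound, and it rests on a reading at the top of the assay's range: the limit of > 100000 nM in this assay, at which 1 of the 4 values shown sits.

From the compounds shown here alone, it remains open whether the loss goes with the added ring itself or with the number of added heavy atoms, which a chloro, methoxy or cyclohexyl group on the same carbon could separate. Going by these compounds, it also remains open whether phenyl here has the same outcome when trifluoromethyl replaces methoxycarbonyl at the other site.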